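The source may hold more compounds than are shown below. What is called first, only, known or untested is meant among the compounds shown, and "the series" means these compounds.

Compound 1 `c1ccc(-c2nnc(-c3cn4ccccc4n3)o2)cc1`: 23400 nM
Compound 2 `COc1ccc(-c2nnc(-c3cn4ccccc4n3)o2)cc1`: 11900 nM
Compound 3 `Cc1cccn2cc(-c3nnc(-c4ccccc4)o3)nc12`: 23400 nM
Compound 4 `COc1ccc(-c2nnc(-c3cn4cccc(C)c4n3)o2)cc1`: not yet measured

In a functional assay on A549 cells (Homo sapiens) for antiproliferative activity, read by MTT assay, with a stated time of 48 h (a higher number here means a weaker inhibitor, a lower number a stronger inhibitor), compound 3 sits level with compound 1, and all three measured values lie within the usual scatter of one another. Compound 4 differs from compound 3 by methoxy in place of hydrogen on an aromatic carbon. The same swap has been measured once, as a 2.0-fold lower number from compound 1 to compound 2 (0.29 log units; within the scatter). The methyl swap gave no change at the digits printed from compound 1 to compound 3 (within the scatter), so the methyl appears to leave the numbers untouched, and a similar small methoxy step seems the best guide, though one pair is thin evidence. The expected change is a 1.8-fold lower number from compound 3 to compound 4 (0.26 log units; within the scatter), which would not stand clear of the scatter. Compound 4 is estimated at 13000 nM, with an expected range of 6000 nM to 28000 nM.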

Compound 4, half-maximal inhibitory concentration: 12800 nM
For compound 4 the middle estimate is 1.0-fold (0.01 log units) above the measured one; measured number inside the range.
By their numbers in this assay, from the lowest: compounds 2, 4, 1 and 3 (each within the scatter of the next).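

On an aromatic carbon of the six-membered aromatic ring of carbon only, para to a large group, methoxy in place of hydrogen now gives a 1.8-fold lower number from compound 3 to compound 4 (0.26 log units; within the scatter) on a second core, matching the first reading: the same change on two cores in this assay, a 2.0-fold lower number (0.29 log units; within the scatter) from compound 1 to compound 2 and a 1.8-fold lower number (0.26 log units; within the scatter) from compound 3 to compound 4, 1.1-fold (0.03 log units) apart, within the scatter of two such steps. Methyl in place of hydrogen, now tried with the methoxy present, gives a 1.1-fold higher number from compound 2 to compound 4 (0.03 log units; within the scatter) and also matches its first reading: the same change on two cores in this assay, no change at the digits printed (within the scatter) from compound 1 to compound 3 and a 1.1-fold higher number (0.03 log units; within the scatter) from compound 2 to compound 4, 1.1-fold (0.03 log units) apart, within the scatter of two such steps. All these steps lie within the scatter, so the two changes repeat across cores, but neither can be said to move the number.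

As far as these compounds go, whether an amine or a carboxylic acid in place of the methoxy or the methyl would move the number clear of the scatter remains open.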